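Aziridinylbenzoquinone series: chain carbamate replacing a methyl

The source may hold more compounds than are shown below. What is called first, only, known or untested is meant among the compounds shown, and "the series" means these compounds.

Measured so far:
Compound 1, `CC1=C(N2CC2)C(=O)C(Cc2ccccc2)=C(N2CC2)C1=O`, 4.69
Compound 2, `CC1=C(N2CC2)C(=O)C(C(C)C)=C(N2CC2)C1=O`, 5.21
Compound 3, `CCCC1=C(N2CC2)C(=O)C(CCC)=C(N2CC2)C1=O`, 4.44

All three share one core and differ only in the two side groups. In a functional assay on L1210 cells (Mus musculus), with a stated time of 12 days (a lower number here means a less potent compound, a higher number a more potent compound, by a factor of ten per unit of this negative logarithm), compound 3 gives the lowest of the three numbers. Compound 1 is its nearest neighbour, standing higher by an amount within the scatter, so no order between compound 3 and compound 1 can be read. Among the measured compounds shown here, compound 2 is furthest, beyond the scatter, and the one counted step, a number 0.52 log units higher from compound 1 to compound 2 (beyond the scatter), is a modest gain.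

Compound 4, `CCCC1=C(N2CC2)C(=O)C(CCOC(N)=O)=C(N2CC2)C1=O`, is not yet measured. Against compound 3 the change is carbamoyloxy in place of methyl on a saturated chain carbon, two bonds along the chain from a double-bonded ring carbon. For the measured compounds named here, the single measured step concerns an exchange directly on a double-bonded ring carbon and says nothing about a change two bonds along a saturated chain, nor about a group carrying a hydrogen-bond donor and acceptors; no measured pair bears on it. In the short name of this assay the expectation for compound 4 is therefore a step of a number 0.16 log units higher from compound 3 to compound 4 (within the scatter), which is no change beyond the scatter, with a wide range. Compound 4 is estimated at 4.6, between 3.9 and 5.3.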

Compound 4, logarithm of the reciprocal of the active concentration, log(1/C): 5.23
Compound 4: the middle estimate sits 0.63 log units below what was measured; low and high end bracket the measured number.
By their numbers in this assay, from the lowest: compounds 3 and 1 (each within the scatter of the next); then compounds 2 and 4 (each within the scatter of the next).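

In this assay, carbamoyloxy in place of methyl on a saturated chain carbon, two bonds along the chain from a double-bonded ring carbon, gives a number 0.79 log units higher from compound 3 to compound 4 (beyond the scatter). Among the compounds shown here, the only earlier step concerned an exchange directly on a double-bonded ring carbon, so this is the first sign that a change further out on a saturated chain can also move the number beyond the scatter, here with a group that brings a hydrogen-bond donor and hydrogen-bond acceptors to a chain that had none. Nothing measured accounts for the size of this step, and its cause stays unassigned.

From the compounds shown here alone, this single pair does not separate the whole carbamoyloxy group from its parts, so it remains open whether 2-hydroxyethyl or 2-methoxyethyl in place of 2-(carbamoyloxy)ethyl would keep the higher number, and what a longer chain such as 3-(carbamoyloxy)propyl would give. Also open, going by these compounds, is whether the same exchange on the remaining propyl group of compound 4, giving two carbamoyloxy chains on the shared core, would add a further step.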